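Notes on a nitroaryl series against a protease

The source may hold more compounds than are shown below. What is called first, only, known or untested is meant among the compounds shown, and "the series" means these compounds.

Compound 1, `Cc1ccc2nc(-c3cccc(NC(=O)CCc4ccccc4)c3)[nH]c2c1`, in an assay on cells for inhibition of matrix metalloproteinase-9 (Homo sapiens), read by fluorescence, with stated times of 15 min and 4 h (on this read-out lower numbers stand for stronger inhibition and higher numbers for weaker inhibition), gives 26600 nM.
Compound 2, `Cc1ccc2nc(-c3cccc([N+](=O)[O-])c3)[nH]c2c1`, in this assay gives 36600 nM.
Compound 3, `O=[N+]([O-])c1ccc(-c2nc3ccccc3o2)cc1`, in this assay gives 36000 nM.

Compound 3 holds the second highest of the three numbers in this assay. Its nearest neighbour is compound 2, and the two values lie within the scatter of each other; compound 1, the furthest, also lies within the scatter of compound 3. Within the data shown here, no pair among the three differs in a single place, so no measured step is available, and the three values together show no difference beyond the scatter.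

Compound 4, `Cc1ccc2nc(-c3ccc([N+](=O)[O-])cc3)oc2c1`, is not yet measured. It differs from compound 3 by methyl in place of hydrogen on an aromatic carbon. No measured pair in the series isolates such a change, so there is no shown step to lean on. Among the measured compounds shown here, a change of this size, with no measured precedent, is expected to give a step in this assay no larger than the scatter, in no particular direction. The expected step of no change at the digits printed from compound 3 to compound 4 (within the scatter) is therefore taken as flat. Compound 4 is estimated at 36000 nM, with a range from 18000 nM to 72000 nM.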

Compound 4, half-maximal inhibitory concentration: 18000 nM
Compound 4: the middle estimate sits 2.0-fold (0.30 log units) above what was measured, within the range that was stated.
By their numbers in this assay, from the lowest: compounds 4, 1, 3 and 2 (each within the scatter of the next, the first and the last beyond it).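

Among these compounds, for the first time, a measured pair isolates methyl in place of hydrogen on an aromatic carbon of a six-membered aromatic ring of carbon only, and this assay records a 2.0-fold lower number from compound 3 to compound 4 (0.30 log units; within the scatter) for this change. At this position, then, the methyl brings no step beyond the scatter, and this single pair does not fix a direction for the change. No data bearing on the reason for this step are available.

Going by these compounds, whether a larger group on this same aromatic carbon, such as an ethyl group, a methoxy group or an amine, would give a step beyond the scatter remains open. Also open, on these data alone, is what a carboxylic acid or an amine in place of the nitro group of compound 4 would give in this assay on this core.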